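This account rests on a few compounds, and the source may have more. Where it says the series, first, only, none or still open, it means among the compounds named here.

Working notes on the series. Compound 1 `Cc1c(-c2cc(Cl)cc(Cl)c2)c(C(=O)O)nn1-c1nc(-c2cccnc2)c(SC(C)C)s1` in a functional assay on BJAB cells (Homo sapiens) for antiproliferative activity, with a stated time of 4 days (a lower number here means that less compound is needed, a higher number that more compound is needed for the effect), gives "not active" (no number reported). Compound 2 `Cc1c(-c2cc(Cl)cc(Cl)c2)c(C(=O)O)nn1-c1nc(-c2cc(Cl)ccc2F)c(SC(C)C)s1` in this assay gives 4800 nM, and compound 3 `Cc1cc(C)cc(-c2c(C)nn(-c3nc(-c4ccc(Cl)c(Cl)c4)c(SC(C)C)s3)c2C(=O)O)c1` gives 2700 nM. Compound 3 carries the lower of the two numbers recorded, yet its gap to compound 2 lies within the scatter, so the two cannot be ordered. Compound 4 `Cc1nn(-c2nc(-c3ccc(Cl)c(Cl)c3)c(SC(C)C)s2)c(C(=O)O)c1-c1cccc(Cl)c1C` is not yet measured; it differs from compound 3 by 3-chloro-2-methylphenyl in place of 3,5-dimethylphenyl on an aromatic carbon. Among the compounds with values here, no measured pair shows this change, so no step size is known. The expectation is a step of about a 1.1-fold higher number from compound 3 to compound 4 (0.05 log units; within the scatter), not beyond the scatter in either direction. Compound 4 is estimated at 3000 nM, within 1000 nM to 10000 nM.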

Compound 4, half-maximal effective concentration: 5100 nM
For compound 4 the middle estimate is 1.7-fold (0.23 log units) below the measured one; the range from low to high includes it.
By their numbers in this assay, from the lowest: compounds 3, 2 and 4 (each within the scatter of the next).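

The first step readable at this position, a 1.9-fold higher number from compound 3 to compound 4 (0.28 log units; within the scatter) in this assay, shows that 3-chloro-2-methylphenyl and 3,5-dimethylphenyl on this aromatic carbon cannot be told apart. Replacing a carbon-only substitution pattern with one carrying chlorine therefore produces no change beyond the scatter here. No measured evidence on a cause is available. This single step alters both substituents on the phenyl ring at once, so their separate contributions remain unresolved. Also open, as far as these compounds go, is how an amine or a hydroxyl on that ring would read.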